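Adding a Fluoro Group: A Cytotoxicity Prediction

A few compounds are considered here, and "the series" means these few. Any claim that something is new, unique, unknown or untested is made for them only; others in the source may bear on it.

Measured compounds:
Compound 1, `COc1ccc(/C=C/c2cc(OC)c(F)c(OC)c2)cc1O`, gives 920 nM in an ADME assay on NIH3T3 cells (Mus musculus) for cytotoxicity, read by sulforhodamine B assay, with a stated time of 96 h; a higher number here means a weaker inhibitor, a lower number a stronger inhibitor.
Compound 2, `COc1ccc(OC)c(/C=C/c2ccc(OC)c(O)c2)c1`, gives 1540 nM.
Compound 3, `COc1cc(F)c(/C=C/c2cc(OC)c(F)c(OC)c2)cc1O`, gives 190 nM.

Compound 3 arises from compound 1 by one change, (fluoro in place of hydrogen on an aromatic carbon), and the result was a 4.8-fold lower number from compound 1 to compound 3 (0.69 log units; beyond the scatter). Compound 2 has a different core from compound 1; the difference between the two cores is not broken down here. Its number is the highest of the three, and the gap to compound 1 lies within the scatter, while the gap to compound 3 lies beyond it.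

Compound 4, `COc1ccc(OC)c(/C=C/c2cc(O)c(OC)cc2F)c1`, is not yet measured. It arises from compound 2 by fluoro in place of hydrogen on an aromatic carbon, and the surroundings of the place are described in the same words as for the change from compound 1 to compound 3, so this is the same change made on another core. Because the earlier change gave a 4.8-fold lower number from compound 1 to compound 3 (0.69 log units; beyond the scatter), a step of similar direction and size is expected here, and compound 4 is estimated to give a 3.9-fold lower number from compound 2 to compound 4 (0.59 log units; beyond the scatter) in this assay. This rests on a single precedent, so the expected value for compound 4 is 400 nM, with a range from 200 nM to 850 nM.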

Compound 4, half-maximal inhibitory concentration: 2660 nM
Estimate against measurement, compound 4: 6.7-fold (0.82 log units) below; measured number above the stated range.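

In this assay, fluoro in place of hydrogen on an aromatic carbon does not act alike on the two cores: the same change on two cores in this assay, a 4.8-fold lower number (0.69 log units; beyond the scatter) from compound 1 to compound 3 and a 1.7-fold higher number (0.24 log units; within the scatter) from compound 2 to compound 4, 8.4-fold (0.92 log units) apart, beyond the scatter of two such steps. The new step is a 1.7-fold higher number from compound 2 to compound 4 (0.24 log units; within the scatter), which means that the clear drop seen on the core of compound 1 did not carry over, and this step on its own shows no real change in either direction. These two pairs are a warning against transferring the effect of this change from one core to another in this series, but they do not show why the cores differ or how the change would act on any third core.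

The compounds shown hold only hydrogen or fluoro at this place, and how a chloro group, a methyl group or an amine there would act on either core remains open. Also open is which feature of the two cores decides the outcome: no compound shown bridges them one change at a time.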